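Dropping the Fluoro Group: From Compound 3 to Compound 4

The compounds below may be only part of what the source reports. "The series", "measured", "known", "first", "only" and "open" are said of these compounds alone.

Measured compounds:
Compound 1, `C=C(C)c1ccc(N2CCN(C(=O)c3oc(C)nc3-c3ccccc3)CC2)cc1`: "not active" (no number reported)
Compound 2, `COc1cc(OC)cc(N2CCN(C(=O)c3oc(C)nc3-c3ccc(F)cc3)CC2)c1`: 38.5 nM
Compound 3, `Cc1nc(-c2ccccc2)c(C(=O)N2CCN(c3ccc(F)cc3)CC2)o1`: > 1000 nM

Of the compounds shown here, three have been measured in a functional assay on HL-60 cells (Homo sapiens) for inhibition, read by MTT assay, with a stated time of 72 h; on this read-out lower numbers stand for stronger inhibition and higher numbers for weaker inhibition. Compound 2 gives 38.5 nM in this assay and is the only one of the three with a single number. Compound 1 is recorded in this assay as "not active" (no number reported), with no number reported. Compound 3 gives > 1000 nM, which is a limit of the assay and not a number. Compound 3 therefore stands at the limit of > 1000 nM in this assay, at which 1 of the 3 values shown sits, and it shares with compound 1 the absence of a reported single value.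

The unmeasured compound 4, `Cc1nc(-c2ccccc2)c(C(=O)N2CCN(c3ccccc3)CC2)o1`, differs from compound 3 in one place: hydrogen in place of fluoro on an aromatic carbon. Among the compounds with values here, no pair of measured compounds differs in a single place, so the size of such a change has not been observed in this assay. With compound 3 already at the limit, the step in this assay from compound 3 to compound 4 is expected to be a step that the limit leaves unreadable from compound 3 to compound 4, that is, none beyond the scatter. Compound 4 is accordingly estimated at 1500 nM in this assay, with a range from 500 nM to 5000 nM, and most likely again reported only as a limit.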

Compound 4, half-maximal inhibitory concentration: 39.1 nM
Estimate against measurement, compound 4: 38-fold (1.58 log units) above, and the stated range ends above it.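

In this assay, the change from 4-fluorophenyl to phenyl gives an at least 25-fold lower number from compound 3 to compound 4 (1.40 log units; beyond the scatter), the first change in a single place that can be read among these compounds. It shows that this position, on an aromatic carbon para to a large group, is far from indifferent to the read-out: one fluorine atom separates a compound with a single number from one without. The value of compound 3 is a limit of the assay, so the step gives only the smallest size the change can have: the limit of > 1000 nM in this assay, at which 1 of the 4 values shown sits.

The compounds shown leave open whether fluoro is singular here or whether another group in its place, such as chloro or an amine, would act alike. They also do not show what the same change does to the 4-fluorophenyl of compound 2.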